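Removing fluoro: one repeated change in the series

This account rests on a few compounds, and the source may have more. Where it says the series, first, only, none or still open, it means among the compounds named here.

Of the compounds shown here, three have been measured in a functional assay on SK-MEL-28 cells (Homo sapiens) for inhibition, read by sulforhodamine B assay, with a stated time of 48 h; a higher number here means a weaker inhibitor of growth, a lower number a stronger inhibitor of growth. Compound 1 `COc1cc(OC)cc(-c2ccc(-c3ccc(C(=N)N)c(F)c3)s2)c1` gives 176 nM. Compound 2 `N=C(N)c1ccc(-c2ccc(-c3ccc(Cl)cc3)s2)cc1F` gives 205 nM, and compound 3 `N=C(N)c1ccc(-c2ccc(-c3ccc(Cl)cc3)s2)cc1` gives 176 nM. Compound 1 and compound 3 are level at the digits printed, and compound 2 sits close to both; no order can be read among the three.

Compound 2 and compound 3 differ in one place: hydrogen in place of fluoro on an aromatic carbon. This change made a 1.2-fold lower number from compound 2 to compound 3 (0.07 log units; within the scatter), a step that stays inside the usual scatter of this assay.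

Compound 4 `COc1cc(OC)cc(-c2ccc(-c3ccc(C(=N)N)cc3)s2)c1` has not been measured. It differs from compound 1 by hydrogen in place of fluoro on an aromatic carbon, the same change as between compound 2 and compound 3, with the same surroundings at the place of change. For the measured compounds named here, compound 1 and compound 2 differ in more than one place; the difference between the two cores is not broken down here, so the only guide for compound 4 is the measured pair.

Given that the change from compound 2 to compound 3 left the number essentially where it was, compound 4 is expected to sit near compound 1, with an estimated step of a 1.2-fold lower number from compound 1 to compound 4 (0.07 log units; within the scatter) in this assay. Going by the values given here, the estimate for compound 4 in this assay is 150 nM, with a range from 75 nM to 300 nM, resting on the single measured step from compound 2 to compound 3.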

Compound 4, concentration for 50% growth inhibition: 1790 nM
Compound 4: the middle estimate sits 12-fold (1.08 log units) below what was measured; measured number above the stated range.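

In this assay, hydrogen in place of fluoro on an aromatic carbon gave a 10-fold higher number from compound 1 to compound 4 (1.01 log units; beyond the scatter), so on the core of compound 1 this change is far from neutral. The change does not carry over from one core to the other with the same size, and the step on one core gives no reliable estimate of the step on the other: the same change on two cores in this assay, a 1.2-fold lower number (0.07 log units; within the scatter) from compound 2 to compound 3 and a 10-fold higher number (1.01 log units; beyond the scatter) from compound 1 to compound 4, 12-fold (1.07 log units) apart, beyond the scatter of two such steps. For the compounds shown here, this does not show why the two steps part, which other cores would follow either pair, or whether the large step would recur on a further core, since only two pairs are at hand and the two cores differ in more than one place.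

Open, from the compounds shown here alone, is what other groups at this same place, on an aromatic carbon of the six-membered aromatic ring of carbon only, would do on the core of compound 1; a nitrile, a trifluoromethyl or a hydroxyl group would each test whether the number stays near that of compound 1 or moves towards that of compound 4. Also open, going by these compounds, is whether the large step persists when the rest of the core changes one place at a time, for instance with an amine or a carboxylic acid on the other outer ring.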